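Swapping the amide substituent on a bromo-substituted scaffold

A few compounds are considered here, and "the series" means these few. Any claim that something is new, unique, unknown or untested is made for them only; others in the source may bear on it.

Measured compounds:
compound 1, `C[C@@H](Nc1c(C(=O)NCc2ccc(F)cc2)nc(Br)c2cccnc12)c1ccccc1`: > 20000 nM
compound 2, `CS(=O)(=O)NCCCN(c1nc(C(=O)NCc2ccc(F)cc2)c(O)c2ncccc12)S(C)(=O)=O`: > 20000 nM
compound 3, `N[C@H]1CC[C@H](Nc2c(C(=O)NCc3cccc(C(F)(F)F)c3)nc(Br)c3cccnc23)CC1`: 4200 nM

The three measured compounds were tested in a functional assay on MDA-MB-435 cells (Homo sapiens) for cytotoxicity, read by MTT assay, with a stated time of 72 h; on this read-out higher numbers stand for weaker inhibition and lower numbers for stronger inhibition. Compound 1 returns only a limit of the assay, > 20000 nM. Compound 2 likewise returns only a limit, > 20000 nM. Going by the values given here, compound 3 is the one compound with a number, 4200 nM; the other two values sit at the limit of > 20000 nM in this assay, at which 2 of the 3 values shown sit, so compound 3 stands alone in the measured series and no step between measured compounds can be drawn.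

Compound 4, `C[C@H](NC(=O)c1nc(Br)c2cccnc2c1N[C@H]1CC[C@H](N)CC1)c1ccc(F)cc1`, has not yet been measured in this assay. It differs from compound 3 in a single place: 1-(4-fluorophenyl)ethyl in place of 3-(trifluoromethyl)benzyl on an amide-type nitrogen. Among the compounds with values here, nothing among the measured compounds shows how such a swap on the amide-type nitrogen affects the read-out, so the step is expected to stay small. The step from compound 3 to compound 4 is estimated as a 1.3-fold higher number from compound 3 to compound 4 (0.12 log units; within the scatter), a slight weakening that may well lie within the scatter. Compound 4 is therefore expected to give 5500 nM, in the range 1500 nM to 20000 nM.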

Compound 4, half-maximal inhibitory concentration: > 10000 nM
Compound 4: a limit, no number; the forecaster's own chance of this, stated with the estimate: 30%; middle value at least 1.8-fold (0.25 log units) away from the limit.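

In this assay, going by these compounds alone, this is the first readable step at the amide-type nitrogen: 1-(4-fluorophenyl)ethyl in place of 3-(trifluoromethyl)benzyl gives an at least 2.3-fold higher number from compound 3 to compound 4 (0.37 log units; beyond the scatter). Within the data shown here, with the rest of the molecule unchanged, the read-out therefore responds to this one swap, which the earlier compounds could not show because none of them formed a one-place pair. Compound 4 carries a limit and not a number, so the true size of the step remains unknown: the limit of > 10000 nM in this assay, at which 1 of the 4 values shown sits.

The compounds shown do not separate the parts of the swap, namely the loss of the trifluoromethyl group, the new fluorine and the new stereocentre. Going by these compounds, it also remains open how a plain benzyl group, a 1-phenylethyl group or the opposite stereoisomer of 1-(4-fluorophenyl)ethyl would read at this position on the same core.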